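Notes on the series: bromo added to compound 3

The compounds below may be only part of what the source reports. "The series", "measured", "known", "first", "only" and "open" are said of these compounds alone.

- compound 1 `CN1C/C(=C\c2ccc(C(F)(F)F)cc2)C(=O)/C(=C/c2cccnc2)C1` in an ADME assay on L02 cells (Homo sapiens) for cytotoxicity, read by MTT assay, with a stated time of 24 h (a lower number here means a stronger inhibitor, a higher number a weaker inhibitor), gives 15600 nM
- compound 2 `CN1C/C(=C\c2ccncc2)C(=O)/C(=C/c2ccc(F)cc2Br)C1` in this assay gives 12400 nM
- compound 3 `O=C1/C(=C/c2cccnc2)CN(S(=O)(=O)c2ccccc2)C/C1=C\c1ccccc1F` in this assay gives 15300 nM

Compound 3 lies within the scatter of both compound 1 and compound 2, and the three values show no order. Compound 4 `O=C1/C(=C/c2cccnc2)CN(S(=O)(=O)c2ccc(Br)cc2)C/C1=C\c1ccccc1F` differs from compound 3 by one change bromo in place of hydrogen on an aromatic carbon in which phenylsulfonyl becomes (4-bromophenyl)sulfonyl: bromo in place of hydrogen on an aromatic carbon, para to a large group. Going by the values given here, no measured pair differs in one place, so no direct precedent exists. With compound 3 at 15300 nM as the closest reference, a small step toward a lower number in this assay is expected, possibly none beyond the scatter. Compound 4 is estimated at 12000 nM with an expected range from 6000 nM to 25000 nM in this series. The estimate amounts to an expected 1.3-fold lower number from compound 3 to compound 4 (0.11 log units; within the scatter) on these numbers.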

Compound 4, half-maximal inhibitory concentration: 14600 nM
Beside the measured number, compound 4's estimate is 1.2-fold (0.09 log units) below it; measured number inside the range.
By their numbers in this assay, from the lowest: compounds 2, 4, 3 and 1 (each within the scatter of the next).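

In this assay the series now has its first pair differing in one place, and bromo in place of hydrogen on an aromatic carbon, para to a large group, gives a 1.0-fold lower number from compound 3 to compound 4 (0.02 log units; within the scatter) with no readable change. At this position, phenylsulfonyl and (4-bromophenyl)sulfonyl therefore cannot be told apart in this read-out. No evidence on the origin of this result is available.

From the compounds shown here alone, whether an amine or a carboxylic acid at the same place would give a step beyond the scatter remains open. So does whether bromo behaves alike on other cores.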